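A Methyl Group Added in Two Different Places

The compounds below may be only part of what the source reports. "The series", "measured", "known", "first", "only" and "open" are said of these compounds alone.

Measured compounds:
compound 1, `COc1cccc(Nc2nccc(-c3cccs3)n2)c1`, gives 900 nM
compound 2, `Cc1cc(C)cc(Nc2nccc(-c3ccco3)n2)c1`, gives 700 nM
compound 3, `COc1cccc(Nc2nccc(-c3sccc3C)n2)c1`, gives > 24000 nM

These three compounds were tested in a functional assay for inhibition, with Homo sapiens as the target; a lower number here means a stronger inhibitor, a higher number a weaker inhibitor. Compound 1 gives 900 nM. Compound 2 gives 700 nM, and the two numbers lie within the usual scatter of each other, so no order between them can be claimed. The value of compound 3 is a limit of the assay rather than a number: compound 3 sits at the limit of > 24000 nM in this assay, at which 1 of the 3 values shown sits. How the cores of compound 1 and compound 2 differ is not broken down here.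

Compound 1 and compound 3 differ in one place: methyl in place of hydrogen on an aromatic carbon. This step made an at least 26-fold higher number from compound 1 to compound 3 (1.42 log units; beyond the scatter), a large loss of inhibition.

The unmeasured compound 4, `Cc1cc(C)cc(Nc2nc(C)cc(-c3ccco3)n2)c1`, is related to compound 2 by the same kind of change: methyl in place of hydrogen on an aromatic carbon. The place is not the same, however. In compound 3 the methyl sits on a five-membered aromatic ring with one sulfur, next to the ring atom that bears a large group; in compound 4 it sits on a six-membered aromatic ring with two nitrogens, next to the ring nitrogen. Among the compounds with values here, the one earlier example points toward weaker inhibition, but it was made at a different place, so the expected step from compound 2 to compound 4 is taken as smaller and uncertain: a 3.6-fold higher number from compound 2 to compound 4 (0.55 log units; beyond the scatter). Compound 4 is therefore expected to give about 2500 nM in this assay, within a range from 500 nM to 15000 nM.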

Compound 4, half-maximal inhibitory concentration: > 24000 nM
Compound 4 was reported as a limit; the forecaster's own chance of this, stated with the estimate: 15%; middle value at least 9.6-fold (0.98 log units) from the limit.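

In this assay compound 4 gives > 24000 nM and this is a limit of the assay, not a number. Methyl in place of hydrogen on an aromatic carbon made an at least 34-fold higher number from compound 2 to compound 4 (1.53 log units; beyond the scatter) and so a large loss of inhibition, just as the same kind of change did at a different place on another core, where it made an at least 26-fold higher number from compound 1 to compound 3 (1.42 log units; beyond the scatter) as its step. This shows that in both of these pairs a single added methyl took inhibition down to the limit of the assay, but it does not show that every such methyl in the series would do so, nor can the sizes of the two losses be compared: (the same change on two cores in this assay, an at least 26-fold higher number (1.42 log units; beyond the scatter) from compound 1 to compound 3 and an at least 34-fold higher number (1.53 log units; beyond the scatter) from compound 2 to compound 4; the limit leaves it open whether they differ).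

Going by these compounds, how much inhibition remains in the two methyl compounds stays unknown, since compound 3 and compound 4 rest on the same limit: (the limit of > 24000 nM in this assay, at which 2 of the 4 values shown sit). Also open, on these data alone, is whether a fluorine atom, an amine or a longer chain in place of these same hydrogens would keep inhibition or lose it as the methyl did, and whether a methyl elsewhere on these compounds, such as on the furan-2-yl group of compound 2, would behave alike.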